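A few compounds are considered here, and "the series" means these few. Any claim that something is new, unique, unknown or untested is made for them only; others in the source may bear on it.

Compound 2, `Cc1c(NCc2nnc(-c3ccccc3Cl)o2)c(=O)n(-c2ccccc2)n1C`, is the most lipophilic of the three compounds measured here in a physicochemical assay for lipophilicity, measured as octanol-water partition (on this read-out lower numbers stand for lower lipophilicity and higher numbers for higher lipophilicity), giving 2.72. Compound 1, `Cc1c(NCc2nnc(Cc3ccccc3)o2)c(=O)n(-c2ccccc2)n1C`, gives 1.64 in this assay, and compound 3, `Cc1ccc(-c2nnc(CNc3c(C)n(C)n(-c4ccccc4)c3=O)o2)cc1`, gives 2.48. The step of a number 1.08 log units higher from compound 1 to compound 2 (beyond the scatter) and the step of a number 0.84 log units higher from compound 1 to compound 3 (beyond the scatter) both show the aromatic groups standing above benzyl, while the step of a number 0.24 log units lower from compound 2 to compound 3 (within the scatter) lies within the scatter.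

Compound 4, `COc1ccc(-c2nnc(CNc3c(C)n(C)n(-c4ccccc4)c3=O)o2)cc1`, is not yet measured in this assay. It differs from compound 2 in one place: 4-methoxyphenyl in place of 2-chlorophenyl on an aromatic carbon. The most informative comparison is the step of a number 0.24 log units lower from compound 2 to compound 3 (within the scatter), which exchanges the same 2-chlorophenyl for another substituted phenyl and moves the number only within the scatter. Among the measured compounds shown here, no measured compound carries a 4-methoxyphenyl, so the added hydrogen-bond acceptor has no direct precedent in this set. On balance a small downward step, a number 0.42 log units lower from compound 2 to compound 4 (beyond the scatter), is expected, somewhat larger than that seen from compound 2 to compound 3, but possibly still within the scatter. The estimated value for compound 4 in this assay is 2.3, with an expected range from 1.9 to 2.7.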

Compound 4, partition coefficient: 2.07
The estimate for compound 4 lay 0.23 log units above the measured number; the range from low to high includes it.
By their numbers in this assay, from the lowest: compound 1; then compound 4; then compounds 3 and 2 (each within the scatter of the next).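

With compound 4, the choice of substituent on the phenyl ring at this position matters in this assay: the step of a number 0.65 log units lower from compound 2 to compound 4 (beyond the scatter) goes beyond the scatter, whereas the earlier exchange of the same 2-chlorophenyl, the step of a number 0.24 log units lower from compound 2 to compound 3 (within the scatter), did not. The closest comparison is the step of a number 0.41 log units lower from compound 3 to compound 4 (beyond the scatter), where methoxy in place of methyl alone separates two phenyl groups that otherwise match, while the step of a number 0.43 log units higher from compound 1 to compound 4 (beyond the scatter) keeps 4-methoxyphenyl above benzyl, as with the other two phenyl groups. Nothing shown here gives a measured reason for these differences.

The compounds shown do not separate the effect of where a substituent sits on the phenyl ring from the effect of which substituent it is, since 2-chlorophenyl carries its chlorine at a different ring position from the methyl and methoxy of the other two groups. From the compounds shown here alone, it also remains open where the number would fall with an amine, a carboxylic acid or a longer chain such as ethoxy on that phenyl ring.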